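The source may report more compounds than this note shows. Statements on the series, on what has been measured and on what is new or still open speak of the compounds shown alone.

Working notes on the series. Compound 1 (`O=[N+]([O-])c1ccc(NC(=S)NCCNS(=O)(=O)c2ccc(-c3ccccc3O[C@H]3CC[C@@H](O)CC3)s2)cc1`), compound 2 (`O=S(=O)(NCCNC(=S)Nc1cccc(Cl)c1)c1ccc(-c2ccccc2OCc2ccccc2)s1`) and compound 3 (`COc1cccc(NC(=O)NCCNS(=O)(=O)c2ccc(-c3ccccc3OCc3ccccc3)s2)c1`) have been read in an ADME assay on HEK-293T cells (Homo sapiens) for cytotoxicity, read by CCK-8 assay, with a stated time of 48 h; a lower number here means a stronger inhibitor, a higher number a weaker inhibitor. Compound 3 gives > 20000 nM, which is a limit of the assay and not a number. Compound 1 gives 20000 nM and compound 2 gives 10200 nM, two values within the scatter of each other.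

Compound 4 (`O=[N+]([O-])c1ccc(NC(=S)NCCNS(=O)(=O)c2ccc(-c3ccccc3OCc3ccccc3)s2)cc1`) is the next to be read. Its change from compound 3 is a group of 12 heavy atoms (7 carbon, 2 nitrogen, 2 oxygen, 1 sulfur; one six-membered aromatic ring of carbon only) in place of a group of 11 heavy atoms (8 carbon, 1 nitrogen, 2 oxygen; one six-membered aromatic ring of carbon only), on an amine nitrogen, at an amine nitrogen whose other neighbours are saturated chain carbon. Within the data shown here, the one measured step that bears on this is an at least 1.9-fold higher number from compound 2 to compound 3 (0.29 log units; that floor lies within the scatter), a replacement on the same amine nitrogen. Its floor stays within the scatter, so it gives only weak guidance on size. The group entering compound 4 contains sulfur, as does the group on compound 2, which gives 10200 nM. The same entering group sits on compound 1, which gives 20000 nM, although the rest of that molecule differs.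

A modest move toward a lower number is therefore expected, possibly no larger than the scatter. The expected step is an at least 1.5-fold lower number from compound 3 to compound 4 (0.18 log units; that floor lies within the scatter). For compound 4 the estimate is 13000 nM, with an expected range of 6000 nM to 25000 nM.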

Compound 4, half-maximal inhibitory concentration: 8900 nM
For compound 4 the middle estimate is 1.5-fold (0.16 log units) above the measured one, within the range that was stated.
By their numbers in this assay, from the lowest: compounds 4, 2 and 1 (each within the scatter of the next, the first and the last beyond it).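

In this assay, among these compounds, an at least 2.2-fold lower number from compound 3 to compound 4 (0.35 log units; beyond the scatter) is the first replacement on this amine nitrogen whose floor clears the scatter, and it is a floor only, with compound 3 resting on a limit of the assay and not on a number: the limit of > 20000 nM in this assay, at which 1 of the 4 values shown sits. On the amide-type nitrogen, a 1.1-fold lower number from compound 2 to compound 4 (0.06 log units; within the scatter) stays within the scatter, so 4-nitrophenyl in place of 3-chlorophenyl gives no readable change in this assay. Away from that end of the molecule, a 2.2-fold lower number from compound 1 to compound 4 (0.35 log units; beyond the scatter) is a modest step beyond the scatter, which shows that benzyl in place of 4-hydroxycyclohexyl on an oxygen on an aromatic ring also moves the number in compounds sharing the entering group.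

The step from (3-methoxyphenyl)carbamoyl changes the sulfur and the ring substituent together, so the compounds shown cannot assign it to either one. Also open, from the compounds shown here alone, is how a carboxylic acid or an amine on the benzyl ring, or a longer chain in place of the saturated chain carbon on the amine nitrogen, would read in this assay.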